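A few compounds are considered here, and "the series" means these few. Any claim that something is new, unique, unknown or untested is made for them only; others in the source may bear on it.

In a physicochemical assay on A549 cells for solubility, read by microscopy, with a stated time of 24 h (a lower number here means a stronger inhibitor, a higher number a weaker inhibitor), compound 2, whose structure is `O=C(N/N=C/c1ccccc1O)c1cc(-c2ccccc2)nn1Cc1ccccc1`, gives 650 nM. Among the two measured compounds this is the higher number, yet compound 1, with the structure `O=C(N/N=C/c1ccccc1O)c1cc(-c2ccccc2)nn1Cc1ccc(Cl)nc1`, gives 440 nM in this assay, and the step of a 1.5-fold higher number from compound 1 to compound 2 (0.17 log units; within the scatter) lies within the scatter, so the two compounds cannot be told apart on these numbers.

Compound 3 has the structure `CC(C)(C)c1ccc(Cn2nc(-c3ccccc3)cc2C(=O)N/N=C/c2ccccc2O)cc1`. It differs from compound 2 in one place: tert-butyl in place of hydrogen on an aromatic carbon, on an aromatic carbon of a six-membered aromatic ring of carbon only. Among the compounds with values here, the only measured step that touches the same part of the molecule is the exchange of the ring on the chain carbon bound to the aromatic nitrogen, from compound 1 to compound 2, which stayed within the scatter. Adding a group to that ring rather than exchanging the ring is a different change, and nothing measured shows what it does here. A step of no more than the scatter is therefore expected, in either direction, with the estimated step written as a 1.1-fold lower number from compound 2 to compound 3 (0.03 log units; within the scatter). Compound 3 is expected to give about 600 nM in this assay, with a range from 250 nM to 1500 nM.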

Compound 3, half-maximal inhibitory concentration: 560 nM
The estimate for compound 3 lay 1.1-fold (0.03 log units) above the measured number; measured number inside the range.
By their numbers in this assay, from the lowest: compounds 1, 3 and 2 (each within the scatter of the next).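

In this assay, tert-butyl in place of hydrogen on an aromatic carbon gives a 1.2-fold lower number from compound 2 to compound 3 (0.06 log units; within the scatter) and so adds 4 heavy atoms, all carbon, to the ring without a difference that these numbers can detect. Compared with the 6-chloropyridin-3-yl group of compound 1, the 4-(tert-butyl)phenyl group gives a 1.3-fold higher number from compound 1 to compound 3 (0.10 log units; within the scatter) and so this exchange also stays inside the normal spread of repeat measurements, which means that 6-chloropyridin-3-yl, phenyl and 4-(tert-butyl)phenyl cannot be told apart at this position in these three compounds. There is no supporting measurement that could explain this result.

As far as these compounds go, it remains open what a different kind of group would do on the same aromatic carbon, such as an amine or a carboxylic acid, and what a longer chain would do in place of the single saturated carbon that links this ring to the aromatic nitrogen. It is also open whether any change at this position can produce a step beyond the scatter, as every step among these three compounds lies within it.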